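Solubility notes on a quinoline-ether series, step to compound 4

The compounds below may be only part of what the source reports. "The series", "measured", "known", "first", "only" and "open" are said of these compounds alone.

Measured so far:
compound 1 `COc1cccc(CNCCCNc2ccnc3cc(Oc4ccccc4)ccc23)c1O` gives 14500 nM
compound 2 `CC(C)(C)c1ccc(Oc2ccc3c(NCCCNCc4ccco4)ccnc3c2)cc1` gives 14500 nM
compound 3 `c1ccc(Oc2ccc3c(NCCCNCc4ccco4)ccnc3c2)cc1` gives 14500 nM

All three values were read in a physicochemical assay for solubility, with a stated time of 18 h, at pH 7.4; on this read-out lower numbers stand for lower solubility and higher numbers for higher solubility. Compound 3 stands level with compound 1 and compound 2 at the digits shown; no ordering among the three is supported. The two measured steps both end at compound 3: no change at the digits printed from compound 1 to compound 3 (within the scatter), and no change at the digits printed from compound 2 to compound 3 (within the scatter). Neither a change on the saturated chain carbon nor removal of the tert-butyl group moved this assay beyond the scatter.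

Compound 4 `c1coc(CNCCCNc2ccnc3cc(-c4cccc5ccccc45)ccc23)c1` has not yet been measured. Against compound 3 the change is naphthalen-1-yl in place of phenoxy on an aromatic carbon. Among the measured compounds shown here, no measured step touches the group on this aromatic carbon, so neither step bears directly on it; both merely show that the read-out has been flat so far. The change removes the single hydrogen-bond acceptor of the leaving group and adds a second six-membered aromatic ring of carbon only. Given the flat history, only a modest downward step is expected, estimated as a 1.8-fold lower number from compound 3 to compound 4 (0.26 log units; within the scatter). Compound 4 is therefore estimated at 8000 nM, with a range from 3000 nM to 15000 nM.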

Compound 4, solubility: 32000 nM
Estimate against measurement, compound 4: 4.0-fold (0.60 log units) below; measured number above the stated range.
By their numbers in this assay, from the lowest: compounds 1, 2 and 3 (each within the scatter of the next); then compound 4.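

In this assay, among the compounds shown here, this aromatic carbon is the first place where one change moves the number beyond the scatter, with naphthalen-1-yl in place of phenoxy giving a 2.2-fold higher number from compound 3 to compound 4 (0.34 log units; beyond the scatter). The earlier steps shown here, no change at the digits printed from compound 1 to compound 3 (within the scatter) and no change at the digits printed from compound 2 to compound 3 (within the scatter), concerned a saturated chain carbon and the removal of tert-butyl, so the flat read-out seen there does not extend to this position, although the step here is modest and rests on a single pair. Nothing available accounts for the direction of this step.

The change adds a second six-membered aromatic ring of carbon only and removes the hydrogen-bond acceptor of phenoxy in one move, so the compounds shown do not separate these two differences; phenyl on this carbon would keep one ring and lack the acceptor, and naphthalen-1-yloxy would keep the acceptor and carry both rings. Also open, on these data alone, is whether the step holds with 2-hydroxy-3-methoxyphenyl in place of furan-2-yl on the saturated chain carbon, and whether a morpholine on this aromatic carbon would sit with compound 3 or with compound 4.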